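The compounds below may be only part of what the source reports. "The series", "measured", "known", "first", "only" and "open" are said of these compounds alone.

Measured so far: compound 1 `c1ccc(-c2ccoc2)c(OCC2=NCCN2)c1`, which in a functional assay for activation of Alpha-1B adrenergic receptor (Homo sapiens), read by calcium flux (on this read-out higher numbers stand for larger maximal responses and lower numbers for smaller maximal responses), gives 111%, and compound 2 `c1ccc(-c2cc[nH]n2)c(OCC2=NCCN2)c1`, which in this assay gives 39%.

Within the data shown here, compound 2 stands lowest of the two numbers, and the only measured step is the large one a number 72 percentage points lower from compound 1 to compound 2 (beyond the scatter). Compound 3 `c1ccc(-c2nccs2)c(OCC2=NCCN2)c1` differs from compound 2 by 1,3-thiazol-2-yl in place of 1H-pyrazol-3-yl on an aromatic carbon. Among the measured compounds shown here, that single step is the only guide, and because a number 72 percentage points lower from compound 1 to compound 2 (beyond the scatter) accompanied the arrival of the one hydrogen-bond donor, its removal here is expected to move the response back up, though by an uncertain amount. Compound 3 is therefore estimated at 80%, between 40% and 115%, an expected step of a number 41 percentage points higher from compound 2 to compound 3 (beyond the scatter).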

Compound 3, largest response reached (reported as maximum), in percent of the reference or control that the assay uses: 100%
Compound 3: middle estimate off by 20 percentage points, on the low side; the measured number falls inside the stated range.
By their numbers in this assay, from the lowest: compound 2; then compound 3; then compound 1.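

In this assay, the response at this aromatic carbon proved recoverable, as 1,3-thiazol-2-yl in place of 1H-pyrazol-3-yl gave a number 61 percentage points higher from compound 2 to compound 3 (beyond the scatter) and so a large rise. Set against furan-3-yl, the same 1,3-thiazol-2-yl gave only a number 11 percentage points lower from compound 1 to compound 3 (beyond the scatter) as a modest step, which leaves 1H-pyrazol-3-yl apart from the other two rings on this read-out. No measurement at hand explains this separation.

From the compounds shown here alone, it remains open whether the hydrogen-bond donor of 1H-pyrazol-3-yl accounts for the low response, and how a phenyl ring or an amine on this carbon would compare.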